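Methoxy replaces sulfamoyl on a benzamide series

This account rests on a few compounds, and the source may have more. Where it says the series, first, only, none or still open, it means among the compounds named here.

Compound 1 `CC(C)(C)c1ccc(C(=O)NCc2ccc(S(N)(=O)=O)cc2)cc1`: 1400 nM
Compound 2 `Cc1cc(CNC(=O)c2ccc(C(C)(C)C)cc2)ccc1C(=O)O`: 160 nM
Compound 3 `O=C(O)c1ccc(CNC(=O)c2ccc3ccccc3c2)cc1`: 1360 nM

Of the compounds shown here, three have been measured in an assay on HeLa cells with Bile acid receptor (Homo sapiens) as the target, read by a luciferase reporter, with a stated time of 24 h; a lower number here means that less compound is needed, a higher number that more compound is needed for the effect. Compound 1 gives 1400 nM, the highest of the three numbers. Compound 3 gives 1360 nM, a value within the scatter of that of compound 1, so the two cannot be told apart. Compound 2 gives 160 nM, a number clearly lower than that of compound 1, beyond the scatter.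

Compound 4 `COc1ccc(CNC(=O)c2ccc(C(C)(C)C)cc2)cc1` has not yet been measured in this assay. Relative to compound 1 the change is methoxy in place of sulfamoyl on an aromatic carbon. Within the data shown here, no step between measured compounds carries this same exchange, so the direction is not fixed by the data; the account can only rest on the values shown. A step of modest size is expected from compound 1 to compound 4, most likely toward a higher number but not clearly beyond the scatter, with the step of a 1.6-fold higher number from compound 1 to compound 4 (0.20 log units; within the scatter) as the estimate. Compound 4 is therefore expected to give about 2200 nM, within a range from 600 nM to 8000 nM.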

Compound 4, half-maximal effective concentration: 150 nM
Beside the measured number, compound 4's estimate is 15-fold (1.17 log units) above it; measured number below the stated range.
By their numbers in this assay, from the lowest: compounds 4 and 2 (each within the scatter of the next); then compounds 3 and 1 (each within the scatter of the next).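

In this assay, methoxy in place of sulfamoyl on an aromatic carbon, para to a large group, gives a 9.3-fold lower number from compound 1 to compound 4 (0.97 log units; beyond the scatter) and so shows that sulfamoyl is not needed at this position for a low number. Among these compounds, the earlier compounds held no step at this position, so this is the first direct reading of a change there; here the entering group has fewer heavy atoms and no hydrogen-bond donor, though the single step cannot show which of these differences matters, if either does. No measurement shown gives a reason for the step.

From the compounds shown here alone, whether hydroxy, ethoxy or an amine at this position would give a number like that of methoxy remains open. Going by these compounds, it is also open whether the same exchange would give a similar step on the core of compound 3.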